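This account rests on a few compounds, and the source may have more. Where it says the series, first, only, none or still open, it means among the compounds named here.

Working notes on the ester series in a functional assay on WiDr cells (Homo sapiens) for inhibition, read by sulforhodamine B assay, with a stated time of 48 h; a lower number here means a stronger inhibitor of growth, a higher number a weaker inhibitor of growth. Compound 1 `O=C(CCCCCc1ccccc1)OCC1COCCOCCOCCOCCOCCO1` returns only a limit: in this assay compound 1 gives > 100000 nM. Compound 2 `O=C(CCCCOc1ccccc1)OCC1COCCOCCOCCOCCOCCO1` likewise returns only a limit, and in this assay compound 2 gives > 100000 nM. The step that the two limits leave unreadable from compound 1 to compound 2 therefore cannot be sized, the change being phenoxy in place of benzyl on a saturated chain carbon, four bonds along the chain from a carbonyl carbon. Where compound 2 stands is thus known only as a limit, and the limit of > 100000 nM in this assay, at which 2 of the 2 values shown sit, is the whole of the evidence on the measured steps. Compound 3 `O=C(OCC1COCCOCCOCCOCCOCCO1)c1cccnc1` is not yet measured in this assay. It differs from compound 2 by pyridin-3-yl in place of 4-phenoxybutyl on a carbonyl carbon. Going by the values given here, no measured step bears on this change, and the one step available is itself unreadable, so no size or direction can be drawn from it. Compound 3 is expected to remain at the limit as well, the step that the limit leaves unreadable from compound 2 to compound 3 being estimated as none beyond the scatter. The estimate for compound 3 is 150000 nM, within 30000 nM to 1000000 nM.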

Compound 3, concentration for 50% growth inhibition: > 100000 nM
Compound 3 gave a limit, no number; the forecaster's own chance of this, stated with the estimate: 85%; the middle value does not contradict the limit.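

Compound 3 also returns only a limit in this assay, so neither step to it, from compound 1 or from compound 2, can be read, and the series rests on one observation: the limit of > 100000 nM in this assay, at which 3 of the 3 values shown sit.

The compounds shown leave open whether any ester on the shared core gives a measurable growth inhibition in this assay, and how large any of these changes would then be.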